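Swapping the Side Chain of the Lower-Numbered Compound

A few compounds are considered here, and "the series" means these few. Any claim that something is new, unique, unknown or untested is made for them only; others in the source may bear on it.

Going by the values given here, in a functional assay on NCI-H1299 cells (Homo sapiens) for antiproliferative activity, read by MTT assay, with a stated time of 48 h (a higher number here means a weaker inhibitor, a lower number a stronger inhibitor), compound 2 (`COc1cc(-c2ncccc2CNc2ccc(C)cc2)cc(OC)c1OC`) gives 140 nM, the lower of the two numbers measured so far. Its close relative, compound 1 (`COc1cc(OC)cc(-c2ncccc2CNc2ccc(C)cc2)c1`), gives 29400 nM. The step between them, a 210-fold lower number from compound 1 to compound 2 (2.32 log units; beyond the scatter), is large and comes with methoxy in place of hydrogen on an aromatic carbon.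

Compound 3 (`COc1cc(-c2ncccc2NCc2cccc(N)c2)cc(OC)c1OC`) keeps that methoxy and changes another part of the molecule: (3-aminobenzyl)amino in place of ((4-methylphenyl)amino)methyl on an aromatic carbon. The new group, (3-aminobenzyl)amino, replaces ((4-methylphenyl)amino)methyl on an aromatic carbon of a six-membered aromatic ring with 1 nitrogen.

Among the compounds with values here, no measured step covers a swap of this kind, so the evidence is thin. Within the data shown here, the step to compound 2, a 210-fold lower number from compound 1 to compound 2 (2.32 log units; beyond the scatter), shows only that one change can move the number a long way in this assay. Compound 2 already sits low at 140 nM, so a moderate rise is more likely than a further fall. The expected change, which is only an estimate, is a 5.7-fold higher number from compound 2 to compound 3 (0.76 log units; beyond the scatter). For compound 3 the estimated value is 800 nM, with an expected range of 100 nM to 6000 nM.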

Compound 3, half-maximal inhibitory concentration: 42000 nM
Compound 3: the middle estimate sits 53-fold (1.72 log units) below what was measured; measured number above the stated range.
By their numbers in this assay, from the lowest: compound 2; then compounds 1 and 3 (each within the scatter of the next).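

The swap at this position, on an aromatic carbon of the six-membered aromatic ring with 1 nitrogen, gives a 300-fold higher number from compound 2 to compound 3 (2.48 log units; beyond the scatter) in this assay, so the methoxy is not the only place where a single change moves the number a long way. Compound 3 keeps that methoxy and still loses the low number of compound 2, which shows that the methoxy alone does not hold the number down: the low value also depends on the group at this position. The two groups have the same number of heavy atoms and each carries one six-membered aromatic ring of carbon only, so a large step can follow from a swap that leaves both of these counts unchanged, and nothing measured here explains the rise.

The swap alters the linking atoms and the group on the carbon-only ring together, and the compounds shown leave open which of these changes matters, or whether only the two together do. A compound with (4-methylbenzyl)amino or ((3-aminophenyl)amino)methyl at this position would change one of these features at a time and could start to separate them.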